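This account rests on a few compounds, and the source may have more. Where it says the series, first, only, none or still open, it means among the compounds named here.

Measured so far in a functional assay on NCI-H157 cells (Homo sapiens) for cytotoxicity, read by resazurin assay, with a stated time of 72 h; a lower number here means a stronger inhibitor, a higher number a weaker inhibitor:
- compound 1 `O=C(/C=C/c1ccc(OCCCCO[N+](=O)[O-])c(O)c1)OCCCCO[N+](=O)[O-]`: > 50000 nM
- compound 2 `COc1cc(/C=C/C(=O)OCc2ccc(OCc3c(-c4ccccc4)no[n+]3[O-])cc2)ccc1O`: > 50000 nM

Compound 1 is known only as a limit, > 50000 nM, and not as a number. Compound 2 is likewise known only as a limit, > 50000 nM. For the measured compounds named here, the series so far therefore reads as the limit of > 50000 nM in this assay, at which 2 of the 2 values shown sit.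

Compound 3 `COc1cc(/C=C/C(=O)OCCCCO[N+](=O)[O-])ccc1OCCCCO[N+](=O)[O-]` has not yet been measured. Its structural change from compound 1 is methyl in place of hydrogen on an oxygen on an aromatic ring, hydroxy to methoxy: methyl in place of hydrogen on an oxygen on an aromatic ring.

Going by the values given here, no measured pair differs in one place, so the data give no size for this change in this assay. No step beyond the usual scatter is expected, in either direction, and a further limit is the likeliest result. This expectation rests on compound 1, whose value is a limit: > 50000 nM. The expected size of the change is a step that the limit leaves unreadable from compound 1 to compound 3. For compound 3 the estimated value is 60000 nM, with an expected range of 25000 nM to 120000 nM.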

Compound 3, half-maximal inhibitory concentration: > 50000 nM
Compound 3 ended at the assay's limit; the forecaster's own chance of this, stated with the estimate: 80%; the middle value is on the limit's open side.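

In this assay compound 1 and compound 3 are both known only as limits, so no step can be read for the change from hydroxy to methoxy: the limit of > 50000 nM in this assay, at which 3 of the 3 values shown sit.

The compounds shown leave open whether this change alters cytotoxicity at all, and how the three compounds rank against one another.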